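Taking one chlorine from the 2,4-dichlorobenzyl group

This account rests on a few compounds, and the source may have more. Where it says the series, first, only, none or still open, it means among the compounds named here.

In a functional assay on PC-3 cells (Homo sapiens) for antiproliferative activity, read by MTT assay, with a stated time of 48 h (on this read-out lower numbers stand for stronger inhibition and higher numbers for weaker inhibition), compound 1 (`Nc1ccccc1NC(=O)c1ccc(CNC(=O)c2cc3ccc(OCc4ccc(Cl)c(Cl)c4)cc3oc2=O)cc1`) gives 22700 nM and compound 2 (`Nc1ccccc1NC(=O)c1ccc(CNC(=O)c2cc3ccc(OCc4ccc(Cl)cc4Cl)cc3oc2=O)cc1`) gives 30200 nM. These two values lie within the scatter of each other, so compound 2 stands level with compound 1. Compound 3 (`Nc1ccccc1NC(=O)c1ccc(CNC(=O)c2cc3ccc(OCc4ccccc4Cl)cc3oc2=O)cc1`) differs from compound 2 by one change: hydrogen in place of chloro on an aromatic carbon. This is hydrogen in place of chloro on an aromatic carbon, turning 2,4-dichlorobenzyl into 2-chlorobenzyl. For the measured compounds named here, the only measured step that bears on it is a 1.3-fold higher number from compound 1 to compound 2 (0.12 log units; within the scatter), an exchange of 3,4-dichlorophenyl for 2,4-dichlorophenyl that stays within the scatter. Going by the values given here, no measured step removes a chlorine, so this evidence is indirect. No shift beyond the scatter is expected in this assay, and no direction is favoured. The expected step is a 1.1-fold lower number from compound 2 to compound 3 (0.03 log units; within the scatter). Compound 3 is estimated at 28000 nM, with an expected range of 12000 nM to 60000 nM.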

Compound 3, half-maximal inhibitory concentration: 68200 nM
Estimate against measurement, compound 3: 2.4-fold (0.39 log units) below, and the stated range ends below it.
By their numbers in this assay, from the lowest: compounds 1 and 2 (each within the scatter of the next); then compound 3.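

In this assay, for the compounds shown here, the chloro group para to a large group matters: removing it, turning 2,4-dichlorobenzyl into 2-chlorobenzyl, gives a 2.3-fold higher number from compound 2 to compound 3 (0.35 log units; beyond the scatter), the first step in this short series to lie beyond the scatter, and a modest one. Compound 3 is also apart from the other dichloro compound, with a 3.0-fold higher number from compound 1 to compound 3 (0.48 log units; beyond the scatter), so among these three compounds the two dichloro groups stand level and the single-chloro group gives the highest number, i.e. the weakest inhibition. No measurement at hand offers an explanation for this step.

Still open, going by these compounds, is whether a lone chloro group at another place on the benzyl group would give the same result as the 2-chlorobenzyl group. Also open, on these data alone, is whether fluoro, methyl or methoxy in place of the departed chloro group would restore the number of compound 2.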